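One Hydroxy Group, Tested Twice on the Same Cells

The source may hold more compounds than are shown below. What is called first, only, known or untested is meant among the compounds shown, and "the series" means these compounds.

Of the compounds shown here, three have been measured in a functional assay on RS4-11 cells (Homo sapiens) for inhibition, read by CCK-8 assay, with a stated time of 48 h; on this read-out higher numbers stand for weaker inhibition and lower numbers for stronger inhibition. Compound 3 `O=S(=O)(NCCNC(=S)Nc1cc(C(F)(F)F)cc(C(F)(F)F)c1)c1ccc(-c2ccccc2OCc2ccccc2)s1` reaches only the limit > 50000 nM in this assay. Compound 1 `O=S(=O)(NCCNC(=S)Nc1cc(C(F)(F)F)cc(C(F)(F)F)c1)c1ccc(-c2ccccc2OCc2cccc(O)c2)s1` differs from it in one place, (hydroxy in place of hydrogen on an aromatic carbon), and in this assay compound 1 gives 12000 nM, which makes the step of an at least 4.1-fold lower number from compound 3 to compound 1 (0.61 log units; beyond the scatter). Compound 2 `O=[N+]([O-])c1ccc(NC(=S)NCCNS(=O)(=O)c2ccc(-c3ccccc3OCc3ccccc3)s2)cc1` gives 11300 nM in this assay; how its core differs from the core of compound 3 is not broken down here. Compound 4 `O=[N+]([O-])c1ccc(NC(=S)NCCNS(=O)(=O)c2ccc(-c3ccccc3OCc3cccc(O)c3)s2)cc1` has not yet been measured and differs from compound 2 by the same change, (hydroxy in place of hydrogen on an aromatic carbon). Because the earlier step of an at least 4.1-fold lower number from compound 3 to compound 1 (0.61 log units; beyond the scatter) began at a limit, its true size is open, so a more modest gain is expected for compound 4, with a step of a 2.3-fold lower number from compound 2 to compound 4 (0.35 log units; beyond the scatter). Compound 4 is therefore estimated at 5000 nM, expected to fall between 1500 nM and 15000 nM.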

Compound 4, half-maximal inhibitory concentration: 10100 nM
Compound 4: middle estimate off by 2.0-fold (0.31 log units), on the low side; the measured number falls inside the stated range.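

Going from benzyl to 3-hydroxybenzyl gives a 1.1-fold lower number from compound 2 to compound 4 (0.05 log units; within the scatter) in this assay and so brings no clear change on this core. The same change did more on the core of compound 3, so its effect does not carry over at one size from core to core: the same change on two cores in this assay, an at least 4.1-fold lower number (0.61 log units; beyond the scatter) from compound 3 to compound 1 and a 1.1-fold lower number (0.05 log units; within the scatter) from compound 2 to compound 4, at least 3.7-fold (0.57 log units) apart, beyond the scatter of two such steps. These two pairs do not show why the cores differ, and the true size of the earlier step stays open, since compound 3 stands at a limit: the limit of > 50000 nM in this assay, at which 1 of the 4 values shown sits.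

On these data alone, it remains open whether a methoxy group or an amine in the same place would behave like the hydroxy group on either core. Also open, as far as these compounds go, is how the 3-hydroxybenzyl group would fare on a core carrying a nitrile instead of the nitro group.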